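The source may report more compounds than this note shows. Statements on the series, on what has been measured and on what is new or still open speak of the compounds shown alone.

Measured so far in a functional assay on DU-145 cells (Homo sapiens) for antiproliferative activity, read by propidium iodide staining, with a stated time of 96 h; on this read-out higher numbers stand for weaker inhibition and lower numbers for stronger inhibition:

- Compound 1 `CC(O)(COc1ccc(S(F)(F)(F)(F)F)cc1)C(=O)Nc1ccc(C#N)cc1C(F)(F)F` gives 16000 nM
- Compound 2 `CC(O)(COc1ccccc1C(F)(F)F)C(=O)Nc1ccc(S(F)(F)(F)(F)F)cc1` gives 7100 nM
- Compound 3 `CC(O)(CS(=O)(=O)c1ccc(F)cc1)C(=O)Nc1ccc(S(F)(F)(F)(F)F)cc1` gives 27700 nM

Compound 3 and compound 1 lie within the usual scatter of each other, so this test cannot tell them apart. Compound 3 at 27700 nM has a clearly higher number than compound 2 at 7100 nM, a gap beyond the scatter. That places compound 3 at the weak end of this small set, level with compound 1.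

The next molecule is compound 4 `CC(O)(CS(=O)(=O)c1cccc(OC(F)(F)F)c1)C(=O)Nc1ccc(S(F)(F)(F)(F)F)cc1`. It carries 3-(trifluoromethoxy)phenyl in place of 4-fluorophenyl on a sulfonyl sulfur, and the rest of compound 3 stays the same: 3-(trifluoromethoxy)phenyl in place of 4-fluorophenyl on a sulfonyl sulfur.

Going by the values given here, no two measured compounds differ in one place only, so the data give no direct measure of a swap like this. All that can be said is that compound 2 at 7100 nM shows lower numbers do occur in this small set, though it differs from compound 3 in more than one place. In this assay a small move toward a lower number is therefore expected, possibly no larger than the scatter. The expected step is a 1.8-fold lower number from compound 3 to compound 4 (0.27 log units; within the scatter). For compound 4 the estimated value is 15000 nM, with an expected range from 5000 nM to 40000 nM.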

Compound 4, half-maximal inhibitory concentration: 26500 nM
Estimate against measurement, compound 4: 1.8-fold (0.25 log units) below; measured number inside the range.
By their numbers in this assay, from the lowest: compound 2; then compounds 1, 4 and 3 (each within the scatter of the next).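

In this assay, putting 3-(trifluoromethoxy)phenyl in place of 4-fluorophenyl on a sulfonyl sulfur gives a 1.0-fold lower number from compound 3 to compound 4 (0.02 log units; within the scatter). Going by these compounds alone, this is the first direct reading of a single swap in this set, and it shows that compound 3 and compound 4 cannot be told apart in this test, even though the entering group has more heavy atoms and adds a hydrogen-bond acceptor. No measured property is available to explain this result.

On these data alone, both groups compared here are substituted phenyl rings, so it remains open whether a group without an aromatic ring, such as cyclohexyl or a simple ethyl chain, or a ring carrying an amine or a carboxylic acid, would be tolerated equally at this sulfonyl sulfur. Within the data shown here, the role of the sulfonyl link itself also remains unresolved: compound 2 has an ether oxygen at that point, but it differs from compound 3 and compound 4 in more than one place, and no step isolates that link.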